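Changing the Halogenated Ring on an Amide

This account rests on a few compounds, and the source may have more. Where it says the series, first, only, none or still open, it means among the compounds named here.

Compound 1, `Cc1ccc(C2=NOC(C)(C)C2=O)cc1-c1cnc(NC(=O)c2c(F)cccc2F)cn1`: 34 nM
Compound 2, `Cc1ccc(C2=NOC(C)(C)C2=O)cc1-c1cnc(NC(=O)c2ccc(F)cc2F)cn1`: "not active" (no number reported)
Compound 3, `Cc1ccc(C2=NOC(C)(C)C2=O)cc1-c1cnc(NC(=O)c2cc(F)ccc2F)cn1`: "not active" (no number reported)

These three compounds share one core and differ only in the fluorine pattern on the ring attached to the carbonyl. In an assay on Jurkat T cells for inhibition of interleukin-2 (Homo sapiens), read by ELISA, with stated times of 10 min and 24 h (a higher number here means a weaker inhibitor, a lower number a stronger inhibitor), compound 1 gives 34 nM. Compound 2 gives "not active" (no number reported), and compound 3 likewise gives "not active" (no number reported), so no number is recorded for either, and compound 3 stands among the compounds without a measured potency. Compound 4, `Cc1ccc(C2=NOC(C)(C)C2=O)cc1-c1cnc(NC(=O)c2ccccc2Cl)cn1`, has not been tested. Its change from compound 3 is 2-chlorophenyl in place of 2,5-difluorophenyl on a carbonyl carbon. Among the measured compounds shown here, no measured step covers this change, so in this assay the direction and size of the step from compound 3 are open; compound 1 shows that a numbered result is possible, while compounds 2 and 3 show that inactivity is common. In this assay compound 4 is estimated at 300 nM, expected within 40 nM to 5000 nM.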

Compound 4, half-maximal inhibitory concentration: 171 nM
Compound 4: middle estimate off by 1.8-fold (0.24 log units), on the high side; the measured number falls inside the stated range.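

Compound 4 gives this series a second numbered result: on the same carbonyl carbon, 2-chlorophenyl in place of 2,6-difluorophenyl still gives a measurable potency in this assay. The change nevertheless gives a 5.0-fold higher number from compound 1 to compound 4 (0.70 log units; beyond the scatter), so this position responds to the choice of ring substituents. No measurement shown here explains the difference.

Steps from compound 2 and compound 3 to compound 4 cannot be read, as neither has a number. Also open, on these data alone, is whether bromine or a methyl group in place of the chlorine, or a cyclohexyl ring in place of the 2-chlorophenyl, would keep a measurable potency.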